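A few compounds are considered here, and "the series" means these few. Any claim that something is new, unique, unknown or untested is made for them only; others in the source may bear on it.

Compound 1 `CC(=O)c1cccc(-c2ccc(C(=O)N(Cc3cccc(OCCCCCC(=O)O)c3)C(C)C)cc2)c1`: in an ADME assay on HepG2 cells (Homo sapiens) for cytotoxicity, read by CellTiter-Glo and resazurin assay, with a stated time of 72 h (a higher number here means that more compound is needed for the effect, a lower number that less compound is needed), compound 1 gives > 26000 nM, which is a limit of the assay and not a number.
Compound 2 `CC(C)N(Cc1cccc(OCCCCCC(=O)O)c1)C(=O)c1ccc(-c2ccco2)cc1`: in this assay compound 2 gives > 26000 nM, again a limit of the assay rather than a number.

Among the compounds with values here, compound 2 therefore stands at the limit, and so does the only other measured compound, since (the limit of > 26000 nM in this assay, at which 2 of the 2 values shown sit). Within the data shown here, the one measured step, a step that the two limits leave unreadable from compound 1 to compound 2, cannot be read because both ends are limits. The change now followed is 3-isopropoxyphenyl in place of furan-2-yl on an aromatic carbon, which gives compound 3 `CC(C)Oc1cccc(-c2ccc(C(=O)N(Cc3cccc(OCCCCCC(=O)O)c3)C(C)C)cc2)c1`. Among the measured compounds shown here, no measured step bears readably on it, and nothing in the two values suggests a reading inside the assay window, so the expected step from compound 2 to compound 3 in this assay is a step that the limit leaves unreadable from compound 2 to compound 3, a step with no readable direction. Compound 3 is accordingly expected to give 40000 nM, with a range from 15000 nM to 100000 nM, most likely reported again as a limit.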

Compound 3, half-maximal effective concentration: > 26000 nM
Compound 3: a limit, no number; the forecaster's own chance of this, stated with the estimate: 80%; the middle value is on the limit's open side.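

Compound 3, like compound 1 and compound 2, sits at a limit of the assay rather than at a number, so none of the steps among these three compounds can be read: the limit of > 26000 nM in this assay, at which 3 of the 3 values shown sit. In this assay the compounds shown leave open whether any of these group changes alters the concentration needed for the effect.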